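The source may report more compounds than this note shows. Statements on the series, on what has been measured and on what is new or still open speak of the compounds shown alone.

Working notes on the series. Compound 1 `CC(C)N(Cc1cccc(OCCCCCC(=O)O)c1)C(=O)c1ccc(-c2ccco2)cc1` in an ADME assay on BJ cells (Homo sapiens) for cytotoxicity, read by CellTiter-Glo and resazurin assay, with a stated time of 72 h (on this read-out lower numbers stand for an effect already at smaller amounts and higher numbers for an effect only at larger amounts of compound), gives no number but a limit, > 26000 nM. Compound 2 `CCOc1cccc(-c2ccc(C(=O)N(Cc3cccc(OCCCCCC(=O)O)c3)C(C)C)cc2)c1` in this assay likewise gives only a limit, > 20800 nM. The step that the two limits leave unreadable from compound 1 to compound 2 is therefore not readable. Compound 3 `CCOC(=O)CCCCCOc1cccc(CN(C(=O)c2ccc(-c3ccc4ccccc4c3)cc2)C(C)C)c1` in this assay also stands at a limit, > 26000 nM. Among the three values shown, two sit at the limit of > 26000 nM in this assay, at which 2 of the 3 values shown sit, and one at the limit of > 20800 nM in this assay, at which 1 of the 3 values shown sits, so compound 3 stands where most of the series stands, with no number to place it within the scatter. Compound 4 `CCOC(=O)CCCCCOc1cccc(CN(C(=O)c2ccc(-c3cc(OC)ccc3F)cc2)C(C)C)c1` differs from compound 3 by 2-fluoro-5-methoxyphenyl in place of naphthalen-2-yl on an aromatic carbon. No readable measured step bears on this change. The expectation is a step that the limit leaves unreadable from compound 3 to compound 4 not beyond the scatter. Compound 4 in this assay is estimated at 30000 nM, ranging from 18000 nM to 60000 nM.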

Compound 4, half-maximal effective concentration: > 26000 nM
Compound 4 was reported as a limit; the forecaster's own chance of this, stated with the estimate: 85%; the middle value does not contradict the limit.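

Compound 3 and compound 4 both stand only at limits in this assay, so no step can be read between them. The compounds shown leave open where any of them would give a measured half-maximal effective concentration.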